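Nitro in Place of Chloro on the Anilino Ring

The source may report more compounds than this note shows. Statements on the series, on what has been measured and on what is new or still open speak of the compounds shown alone.

Three compounds sharing one core were tested in a functional assay on MGC-803 cells (Homo sapiens) for cytotoxicity, read by MTT assay, with a stated time of 72 h; a higher number here means a weaker inhibitor, a lower number a stronger inhibitor. Compound 1 `FC(F)(F)c1ccc(CSc2nc(Nc3ccccc3Cl)c3ccccc3n2)cc1` gives only a limit of this assay, > 50000 nM. Compound 2 `Cc1ccccc1Nc1nc(SCc2ccc(C(F)(F)F)cc2)nc2ccccc12` gives 24400 nM, and compound 3 `FC(F)(F)c1ccc(CSc2nc(Nc3ccc(Cl)cc3)c3ccccc3n2)cc1` gives 16800 nM, the lowest of the two numbers, though the gap a 1.5-fold lower number from compound 2 to compound 3 (0.16 log units; within the scatter) stays within the scatter. The two steps away from the limit, an at least 2.0-fold lower number from compound 1 to compound 2 (0.31 log units; beyond the scatter) and an at least 2.9-fold lower number from compound 1 to compound 3 (0.47 log units; beyond the scatter), are each at least modest.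

Compound 4 `O=[N+]([O-])c1ccc(Nc2nc(SCc3ccc(C(F)(F)F)cc3)nc3ccccc23)cc1` differs from compound 3 by nitro in place of chloro on an aromatic carbon, on an aromatic carbon of a six-membered aromatic ring of carbon only, para to a large group. Going by the values given here, no measured step exchanges chloro for nitro. The nearest, an at least 2.0-fold lower number from compound 1 to compound 2 (0.31 log units; beyond the scatter), exchanges chloro for methyl and is at least modest, while a 1.5-fold lower number from compound 2 to compound 3 (0.16 log units; within the scatter), which alters the aryl group on the nitrogen, stays within the scatter. Hence no step beyond the scatter is expected in this assay, and the estimate for compound 4 is 15000 nM, between 5000 nM and 45000 nM, a step of a 1.1-fold lower number from compound 3 to compound 4 (0.05 log units; within the scatter).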

Compound 4, half-maximal inhibitory concentration: 8170 nM
The estimate for compound 4 lay 1.8-fold (0.26 log units) above the measured number; the measured number falls inside the stated range.
By their numbers in this assay, from the lowest: compound 4; then compounds 3 and 2 (each within the scatter of the next). At a limit, above all of these: compound 1.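

Exchanging chloro for nitro para to a large group gives a step beyond the scatter, a 2.1-fold lower number from compound 3 to compound 4 (0.31 log units; beyond the scatter), so in this assay the number at this place responds to the group it carries, with the rest of the aryl group unchanged. The 4-nitrophenyl group also clears the scatter against the 2-methylphenyl group, a 3.0-fold lower number from compound 2 to compound 4 (0.48 log units; beyond the scatter), a separation the 4-chlorophenyl group did not reach, and against the 2-chlorophenyl group, an at least 6.1-fold lower number from compound 1 to compound 4 (0.78 log units; beyond the scatter). That last step is only bounded, as compound 1 stands at a limit of the assay: the limit of > 50000 nM in this assay, at which 1 of the 4 values shown sits.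

On these data alone, whether the change is particular to nitro or extends to other groups at this place, such as an amine, a nitrile or a carboxylic acid, stays open. Also open, as far as these compounds go, is whether nitro would have the same effect at the place held by the chloro of compound 1.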